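The source may hold more compounds than are shown below. What is called first, only, known or untested is meant among the compounds shown, and "the series" means these compounds.

The compounds measured in an ADME assay on PC-3 cells (Homo sapiens) for cytotoxicity, read by WST assay, tested at 100 uM (a higher number here means more inhibition at the concentration tested (going by the name of the read-out), a lower number less inhibition), so far:

compound 1 `Cc1cccc(C(=O)N2CCCC(C(=O)Nc3ccc(Cl)cc3)C2)c1` — compound 1 gives 0%
compound 2 `C=CCOc1cccc(NC(=O)C2CCCN(C(=O)c3cc(C(F)(F)F)cc(C(F)(F)F)c3)C2)c1` — compound 2 gives 0%
compound 3 `O=C(Nc1cccc(S(=O)(=O)N2CCCC2)c1)C1CCCN(C(=O)c2cc(C(F)(F)F)cc(C(F)(F)F)c2)C1` — compound 3 gives 0%

On these numbers compound 1 stands level with compounds 2 and 3 at the digits shown. Its nearest neighbour is compound 2, with no change within the scatter, and its furthest is compound 3, again with no change within the scatter. All three share a core in which a piperidine-type amide is linked to two aromatic rings, and none of them shows inhibition in this assay.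

Compound 4 `CC(C)(C)CC(=O)Nc1cccc(C(=O)N2CCCC(C(=O)Nc3ccc(Cl)cc3)C2)c1` has not yet been measured. It differs from compound 1 by (neopentylcarbonyl)amino in place of methyl on an aromatic carbon.

Among the compounds with values here, only one measured step is available, no change at the digits printed from compound 2 to compound 3 (within the scatter), and it concerns an exchange of groups on an aromatic carbon of a different ring from the one altered here. Within the data shown here, no step in the set matches the entry of (neopentylcarbonyl)amino in place of methyl. Among the measured compounds shown here, every compound measured stands level with compound 1, which gives 0%, and the one step shows no movement. On that basis the expected step for compound 4 is no change at the digits printed from compound 1 to compound 4 (within the scatter), none beyond the scatter.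

Compound 4 is therefore estimated at 0%, with an expected range from 0% to 15%.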

Compound 4, a percentage reported as inhibition, at one concentration (the size of the read-out at that concentration, not a potency): 0%
For compound 4 middle estimate and measured number coincide at the digits printed; measured number inside the range.
By their numbers in this assay, from the lowest: compounds 1, 2, 3 and 4 (each within the scatter of the next).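

In this assay, the entry of (neopentylcarbonyl)amino in place of methyl on an aromatic carbon, meta to a large group, gives no change at the digits printed from compound 1 to compound 4 (within the scatter). Within the data shown here, this is the first reading of a change on this ring, as the only earlier step, no change at the digits printed from compound 2 to compound 3 (within the scatter), lay on a different ring, and it shows that a group of 8 heavy atoms carrying a hydrogen-bond donor and a hydrogen-bond acceptor can replace a single methyl carbon here with no inhibition appearing at the concentration tested. No measurement is available that bears on why the read-out stays flat across this change.

With compound 4 at 0%, like every other compound shown, the series offers no level from which a fall could be seen, and it gives no sign of what would raise the read-out at this position. From the compounds shown here alone, whether an amine, a carboxylic acid or a longer chain in place of the (neopentylcarbonyl)amino would produce any inhibition in this assay remains open, as does the effect of such groups on the other ring.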